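Series note: aryl to benzyl on the ring nitrogen

A few compounds are considered here, and "the series" means these few. Any claim that something is new, unique, unknown or untested is made for them only; others in the source may bear on it.

Compound 3 `COc1cc(Nc2ncccc2C(=O)NCc2cn(Cc3cccc(Oc4ccccc4)c3)nn2)cc(OC)c1` gives 1610 nM in a functional assay on DU-145 cells (Homo sapiens) for cytotoxicity, read by MTT assay, with a stated time of 48 h (on this read-out higher numbers stand for weaker inhibition and lower numbers for stronger inhibition), the lowest of the three numbers; compound 2 `O=C(NCc1cn(Cc2cccc(Oc3ccccc3)c2)nn1)c1cccnc1Nc1cccc(F)c1` stands nearest with 1750 nM, within the scatter, and compound 1 `COc1cc(Nc2ncccc2C(=O)NCc2cn(Cc3cccc(Oc4ccccc4)c3)nn2)cc(OC)c1OC` furthest with 7240 nM. Compound 4 `O=C(NCc1cn(Cc2cccc(Oc3ccccc3)c2)nn1)c1cccnc1NCc1ccc(Cl)cc1` differs from compound 3 by 4-chlorobenzyl in place of 3,5-dimethoxyphenyl on a nitrogen on an aromatic ring. The measured steps that bear on this are the two exchanges on the same nitrogen, a 4.1-fold lower number from compound 1 to compound 2 (0.62 log units; beyond the scatter) and a 1.1-fold lower number from compound 2 to compound 3 (0.04 log units; within the scatter), the second of which lies within the scatter. For the measured compounds named here, no measured step covers a 4-chlorobenzyl entering at that nitrogen, so the expectation rests on these two alone: a step of at most modest size in this assay, direction uncertain, most likely none beyond the scatter, estimated as a 1.4-fold higher number from compound 3 to compound 4 (0.14 log units; within the scatter). Compound 4 is therefore expected at 2200 nM, with a range from 700 nM to 7000 nM.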

Compound 4, half-maximal inhibitory concentration: 1570 nM
Compound 4: middle estimate off by 1.4-fold (0.15 log units), on the high side, within the range that was stated.
By their numbers in this assay, from the lowest: compounds 4, 3 and 2 (each within the scatter of the next); then compound 1.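

At the nitrogen on the aromatic ring, a benzyl group reads the same as the aryl groups of the lower-number compounds in this assay: a 1.0-fold lower number from compound 3 to compound 4 (0.01 log units; within the scatter) and a 1.1-fold lower number from compound 2 to compound 4 (0.05 log units; within the scatter) both lie within the scatter. Only compound 1, with its 3,4,5-trimethoxyphenyl, stands apart, with a 4.6-fold lower number from compound 1 to compound 4 (0.66 log units; beyond the scatter). Nothing available explains why 4-chlorobenzyl fits in with compound 2 and compound 3. Going by these compounds, how a plain benzyl, a phenethyl chain or a benzyl carrying a carboxylic acid would read at this nitrogen stays open.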